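From methyl to bromo: estimating a clearance

The source may report more compounds than this note shows. Statements on the series, on what has been measured and on what is new or still open speak of the compounds shown alone.

Values from an in vitro ADME assay on microsomes from liver (Homo sapiens) for pharmacokinetics, read by LC-MS (on this read-out lower numbers stand for slow clearance and higher numbers for fast clearance), for the measured compounds
compound 1 `Cc1cccc2c1nc(C)n2-c1ccc(C(=O)NC2CC2)s1` (10 mL/min/kg)
compound 2 `Cc1nc2cc(C(F)(F)F)ccc2n1-c1ccc(C(=O)NC2CC2)s1` (4 mL/min/kg)

Compound 1 has the higher number of the two (10 mL/min/kg), and compound 2 sits lower by more than the usual scatter. Compound 3 `Cc1nc2c(Br)cccc2n1-c1ccc(C(=O)NC2CC2)s1` keeps the core of compound 1 but has bromo in place of methyl on an aromatic carbon. Among the compounds with values here, no measured pair shows this swap alone. Within the data shown here, compound 2 (4 mL/min/kg) gives the only hint that lower numbers are reachable, so a small drop in this assay is expected, within the scatter. The estimated change is a 1.4-fold lower number from compound 1 to compound 3 (0.15 log units; within the scatter) and no more. Compound 3 is expected at 7 mL/min/kg with 3.5 mL/min/kg to 14 mL/min/kg as the estimated range.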

Compound 3, clearance: 5 mL/min/kg
For compound 3 the middle estimate is 1.4-fold (0.15 log units) above the measured one; low and high end bracket the measured number.
By their numbers in this assay, from the lowest: compounds 2, 3 and 1 (each within the scatter of the next, the first and the last beyond it).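

In this assay, bromo in place of methyl on this aromatic carbon gives a 2.0-fold lower number from compound 1 to compound 3 (0.30 log units; within the scatter) and so leaves the clearance within the usual scatter. Within the data shown here, this is the first pair here that differs in this one place, so the swap can be read on its own. Nothing available explains this result. Still open, from the compounds shown here alone, is whether an amine, a carboxylic acid or a nitrile on this carbon would move the clearance beyond the scatter. Also open, going by these compounds, is whether the same swap would give a similar step on another core.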